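The compounds below may be only part of what the source reports. "The series", "measured", "known", "first", "only" and "open" are said of these compounds alone.

Compound 2 `CCOC(=O)[C@@H]1/C(=C/C(=O)c2ccc(F)cc2)N=C(C)/C(=C(/O)OCC)[C@H]1c1ccccc1C(F)(F)F` shows the highest of the two numbers in a functional assay (aorta) for inhibition, with Oryctolagus cuniculus as the target (on this read-out higher numbers stand for weaker inhibition and lower numbers for stronger inhibition), at 150000 nM; compound 1 `CCOC(=O)[C@@H]1/C(=C/C(=O)c2ccncc2)N=C(C)/C(=C(/O)OCC)[C@H]1c1ccccc1C(F)(F)F` gives 3100 nM in this assay. Within the data shown here, the only recorded step is a 48-fold higher number from compound 1 to compound 2 (1.68 log units; beyond the scatter), a change in the same aryl group on the carbonyl carbon. Among the measured compounds shown here, compound 3 `CCOC(=O)[C@@H]1/C(=C/C(=O)c2ccc(N(C)C)cc2)N=C(C)/C(=C(/O)OCC)[C@H]1c1ccccc1C(F)(F)F` differs from compound 2 by dimethylamino in place of fluoro on an aromatic carbon, a change for which no step is recorded. Compound 3 is expected to land between the two measured values, because the step of a 48-fold higher number from compound 1 to compound 2 (1.68 log units; beyond the scatter) shows this aryl group matters, so an estimated step of a 7.5-fold lower number from compound 2 to compound 3 (0.88 log units; beyond the scatter) is expected. Compound 3 is estimated at 20000 nM, ranging from 3000 nM to 120000 nM.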

Compound 3, half-maximal inhibitory concentration: 2700 nM
Compound 3: middle estimate off by 7.4-fold (0.87 log units), on the high side, and the stated range ends above it.
By their numbers in this assay, from the lowest: compounds 3 and 1 (each within the scatter of the next); then compound 2.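

With only the para substituent changed on the carbon-only aromatic ring, this assay shows a 56-fold lower number from compound 2 to compound 3 (1.74 log units; beyond the scatter), so the high number of compound 2 goes with the fluoro rather than with that ring as such. The further step, a 1.1-fold lower number from compound 1 to compound 3 (0.06 log units; within the scatter), shows that the 4-(dimethylamino)phenyl group and the pyridin-4-yl group cannot be told apart here, so a ring nitrogen is not needed for this level of inhibition. Nothing available explains this match. As far as these compounds go, it remains open whether a primary amine, a methoxy group or a bare phenyl ring would read like compound 2 or like compound 3.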